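A hydroxy group leaves a sulfur-linked chain

The source may report more compounds than this note shows. Statements on the series, on what has been measured and on what is new or still open speak of the compounds shown alone.

Measured in a functional assay on MOLT-4 cells (Homo sapiens), with a stated time of 96 h (on this read-out higher numbers stand for weaker inhibition and lower numbers for stronger inhibition), so far:
compound 1 `CCCSC[C@H]1OC(n2cnc3c(N)ncnc32)[C@H](O)[C@@H]1O` gives 45000 nM on this read-out
compound 2 `Nc1ncnc2c1ncn2C1O[C@H](CSCCCF)[C@@H](O)[C@H]1O` gives 25000 nM on this read-out
compound 3 `Nc1ncnc2c1ncn2C1O[C@H](CSCCO)[C@@H](O)[C@H]1O` gives 40000 nM on this read-out

Compound 3 stands level with the other two, as all three values lie within the usual scatter of one another. Even the widest gap among them, (a 1.8-fold lower number from compound 1 to compound 2 (0.26 log units; within the scatter)), stays inside it.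

Compound 4 (`CCSC[C@H]1OC(n2cnc3c(N)ncnc32)[C@H](O)[C@@H]1O`) has not yet been measured. It differs from compound 3 as follows: hydrogen in place of hydroxy on a saturated chain carbon, two bonds along the chain from a sulfur. In words, this is hydrogen in place of hydroxy on a saturated chain carbon, two bonds along the chain from a sulfur, so that 2-hydroxyethyl becomes ethyl.

Within the data shown here, no measured step makes exactly this change. Among the measured compounds shown here, two steps bear on the same carbon and end at the hydroxy group of compound 3, namely (a 1.1-fold lower number from compound 1 to compound 3 (0.05 log units; within the scatter)) and (a 1.6-fold higher number from compound 2 to compound 3 (0.20 log units; within the scatter)). Neither goes beyond the scatter, so no step beyond the scatter is expected in this assay here. The expected step is small (no change at the digits printed from compound 3 to compound 4 (within the scatter)). Compound 4 is estimated at 40000 nM with an expected range from 20000 nM to 80000 nM on this read-out.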

Compound 4, half-maximal inhibitory concentration: 20000 nM
For compound 4 the middle estimate is 2.0-fold (0.30 log units) above the measured one; measured number inside the range.
By their numbers in this assay, from the lowest: compounds 4, 2, 3 and 1 (each within the scatter of the next, the first and the last beyond it).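

Among these compounds, removing the hydroxy group to turn 2-hydroxyethyl into ethyl gives, in this assay, a 2.0-fold lower number from compound 3 to compound 4 (0.30 log units; within the scatter), so this is the first direct reading of that change, and the hydroxy group on this saturated chain carbon, two bonds along the chain from a sulfur, can be lost without a step beyond the scatter. Hydrogen in place of fluoromethyl at the same carbon also stays inside the scatter, with a 1.3-fold lower number from compound 2 to compound 4 (0.10 log units; within the scatter). Hydrogen in place of methyl at this carbon gives a 2.3-fold lower number from compound 1 to compound 4 (0.35 log units; beyond the scatter), a modest step and the only one among the four compounds that lies beyond the scatter, so this position is not wholly silent, though every value remains in the same broad range. The data shown offer no measurement that would account for that single step.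

As far as these compounds go, what an amine or a carboxylic acid on this carbon would do in this assay remains open. So does whether a longer chain on the sulfur would follow the small differences seen here or produce a larger step.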